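This account rests on a few compounds, and the source may have more. Where it says the series, first, only, none or still open, it means among the compounds named here.

Compound 3 `CC(O)(C(=O)Nc1ccc(S(=O)(=O)N2CCNCC2)cc1)C(F)(F)F` carries piperazin-1-yl on the sulfonyl sulfur. In an assay on a protein complex (Cavia porcellus) with sulfonylurea receptors; K-ATP channels (Homo sapiens) as the target (on this read-out lower numbers stand for stronger inhibition and higher numbers for weaker inhibition), compound 3 gives only a limit, > 30000 nM. Compound 1 `CCC(C)N(C(C)CC)S(=O)(=O)c1ccc(NC(=O)C(C)(O)C(F)(F)F)cc1`, with bis(sec-butyl)amino at that sulfur, in this assay likewise reports a limit, > 30000 nM. The step from compound 1 to compound 3 is therefore a step that the two limits leave unreadable from compound 1 to compound 3. Compound 2 `Cn1nnnc1-c1ccc(NC(=O)C(C)(O)C(F)(F)F)cc1` in this assay gives 30900 nM. Two of the three values shown sit at the limit of > 30000 nM in this assay, at which 2 of the 3 values shown sit, so the measured step gives no readable size. Compound 4 `CC(O)(C(=O)Nc1ccc(S(=O)(=O)N2CCOCC2)cc1)C(F)(F)F` differs from compound 3 by morpholin-4-yl in place of piperazin-1-yl on a sulfonyl sulfur. Within the data shown here, no measured step bears directly on this exchange, and no movement beyond the scatter is expected. In this assay compound 4 is expected to give an estimated 30000 nM with an expected range from 8000 nM to 100000 nM. The expected step from compound 3 to compound 4 is a number no higher from compound 3 to compound 4 (the limit leaves the size open).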

Compound 4, half-maximal inhibitory concentration: 5850 nM
Compound 4: middle estimate off by 5.1-fold (0.71 log units), on the high side, and the stated range ends above it.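

The sulfonyl sulfur substituent can move the value in this assay: morpholin-4-yl in place of piperazin-1-yl gives an at least 5.1-fold lower number from compound 3 to compound 4 (0.70 log units; beyond the scatter), and morpholin-4-yl in place of bis(sec-butyl)amino gives an at least 5.1-fold lower number from compound 1 to compound 4 (0.70 log units; beyond the scatter). The true size of both steps stays open, and the step between the two limits cannot be read, because compound 1 and compound 3 each report a limit rather than a number: the limit of > 30000 nM in this assay, at which 2 of the 4 values shown sit.

Whether the ring oxygen of morpholin-4-yl or the loss of the hydrogen-bond donor of piperazin-1-yl accompanies the lower number remains unresolved. Piperidin-1-yl and 4-methylpiperazin-1-yl on the sulfonyl sulfur are not among the compounds shown, so their values remain open.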